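This account rests on a few compounds, and the source may have more. Where it says the series, first, only, none or still open, it means among the compounds named here.

Compound 2, `CCCCCCCC/C=C\CCCCCCCC(=O)O[C@H]1CCCO[C@@H]1COP(=O)(O)OC[C@H](N)C(=O)O`, gives "not active" (no number reported) in an assay on HEK293-A cells for agonist activity at probable G-protein coupled receptor 34 (Mus musculus), with a stated time of 1.5 h; a lower number here means a smaller maximal response, a higher number a larger maximal response: it is recorded there as not active, so there is no number to place it against the others. Two other compounds were run in the same test. Compound 1, `N[C@@H](COP(=O)(O)O[C@@H]1CCCO[C@@H]1COC(=O)CCc1ccccc1OCc1cccc(Oc2ccccc2)c1)C(=O)O`, gives 14.8% in this assay. Compound 3, `Cc1ccc(Oc2cccc(COc3ccccc3CCC(=O)O[C@@H]3CCCO[C@@H]3COP(=O)(O)OC[C@H](N)C(=O)O)c2)cc1`, gives 16% in this assay. The new compound is compound 4, `CCCCCCCC/C=C\CCCCCCCC(=O)O[C@@H]1CCCO[C@@H]1COP(=O)(O)OC[C@H](N)C(=O)O`. Set against compound 2 the difference is the two compounds have the same atoms and bonds; at least one stereo element is drawn with a configuration in one of them and without one in the other: 1 of 5 stereo elements differ; a stereocentre at a saturated ring carbon is drawn S in compound 2 and R in compound 4. The ring stereocentre of compound 4 is drawn as in compound 1 and compound 3, the two compounds that do give a number, while compound 2 with the other drawing gives none. Within the data shown here, no measured pair shows what such a change alone does, so the direction rests only on that contrast. Compound 4 is expected to give a measurable maximal response in this assay of about 15%, estimated between 3% and 40%, with a fair chance it is again recorded as not active.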

Compound 4, largest response reached (Emax), in percent of the reference or control that the assay uses: "not active" (no number reported)
Compound 4 has no reported number here, so the estimate cannot be set against anything.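

Compound 2 and compound 4 are both recorded as not active in this assay, so no step can be read between them, and nothing shown accounts for that result. Left open is whether the ring stereocentre alone changes the maximal response in any compound that gives a number.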